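From 4-nitrophenyl to 4-chlorophenyl: a step yet unmeasured

A few compounds are considered here, and "the series" means these few. Any claim that something is new, unique, unknown or untested is made for them only; others in the source may bear on it.

Compound 1 `O=C1/C(=C/c2cccnc2)CN(S(=O)(=O)c2ccc(Cl)cc2)C/C1=C\c1ccccc1F` gives 12400 nM
Compound 2 `O=C1/C(=C/c2ccncc2)CNC/C1=C\c1ccccc1F` gives 8200 nM
Compound 3 `O=C1/C(=C/c2ccncc2)CN(S(=O)(=O)c2ccc([N+](=O)[O-])cc2)C/C1=C\c1ccccc1F` gives 11300 nM

In a functional assay on HepG2 cells (Homo sapiens) for cytotoxicity, read by MTT assay, with a stated time of 24 h (a lower number here means a stronger inhibitor, a higher number a weaker inhibitor), compound 3 (11300 nM) lies within the scatter of both other measured compounds. Compound 4 `O=C1/C(=C/c2ccncc2)CN(S(=O)(=O)c2ccc(Cl)cc2)C/C1=C\c1ccccc1F` has not yet been measured. It differs from compound 3 in one place, with chloro in place of nitro on an aromatic carbon, para to a large group (chloro in place of nitro on an aromatic carbon). Within the data shown here, no measured pair shows this change alone, so the estimate has no direct precedent. Compound 1 (12400 nM) and compound 2 (8200 nM) also lie within the scatter of each other, and on that narrow spread no step beyond the scatter, in either direction, is expected in this assay. The expected change is a 1.0-fold lower number from compound 3 to compound 4 (0.01 log units; within the scatter), a small estimated move with no firm direction. Compound 4 is estimated at 11000 nM, within an expected range (6000 nM to 19000 nM).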

Compound 4, half-maximal inhibitory concentration: 5300 nM
Compound 4: middle estimate off by 2.1-fold (0.32 log units), on the high side, outside the stated range (below it).
By their numbers in this assay, from the lowest: compounds 4, 2, 3 and 1 (each within the scatter of the next, the first and the last beyond it).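

In this assay, among these compounds, the change from nitro to chloro on the aromatic carbon para to a large group gives a readable step, a 2.1-fold lower number from compound 3 to compound 4 (0.33 log units; beyond the scatter), so the group at this position matters even though the earlier compounds all lay within the scatter of one another. The pyridine attachment matters too: with the (4-chlorophenyl)sulfonyl group held fixed, pyridin-4-yl in place of pyridin-3-yl gives a 2.3-fold lower number from compound 1 to compound 4 (0.37 log units; beyond the scatter). By contrast, placing (4-chlorophenyl)sulfonyl on the ring amine nitrogen gives a 1.5-fold lower number from compound 2 to compound 4 (0.19 log units; within the scatter), which stays within the scatter.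

On these data alone, whether a methoxy or an amine at this aromatic carbon would read like chloro or like nitro remains open, as does whether the pyridin-4-yl step holds with a 4-nitrophenyl sulfonyl group. Nothing shown here accounts for any of these steps.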